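The source may report more compounds than this note shows. Statements on the series, on what has been measured and on what is new or still open speak of the compounds shown alone.

Compound 1 `Cc1ccccc1-c1cc(C(=O)N2CCC3(CC2)CC(=O)c2nn(C(C)(C)C)cc2O3)c2ccccc2n1`: > 10000 nM
Compound 2 `CC(C)(C)n1cc2c(n1)C(=O)CC1(CCN(C(=O)c3cc(N4CCNCC4)nc4ccccc34)CC1)O2`: 8570 nM

Among the measured compounds shown here, in a functional assay on HepG2 cells (Homo sapiens) for inhibition, read by MTT assay, with a stated time of 72 h (a lower number here means a stronger inhibitor, a higher number a weaker inhibitor), compound 2 gives 8570 nM, the only actual number so far. Compound 1 gives > 10000 nM, which is a limit and not a number.

The next compound is compound 3 `Cc1cc(C(=O)N2CCC3(CC2)CC(=O)c2nn(C(C)(C)C)cc2O3)c2ccccc2n1`. It keeps the shared core of compound 2 but changes one group: methyl in place of piperazin-1-yl on an aromatic carbon. In words, methyl takes the place of piperazin-1-yl on an aromatic carbon, next to the ring nitrogen.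

For the measured compounds named here, only one measured step bears on this change. It put piperazin-1-yl in place of 2-methylphenyl on an aromatic carbon, and it gave an at least 1.1-fold lower number from compound 1 to compound 2 (0.06 log units; that floor lies within the scatter). That step does not show that piperazin-1-yl makes any real difference in this assay, so no large shift is expected when this group leaves. If anything, a slightly higher number is expected. The estimated change is a 1.4-fold higher number from compound 2 to compound 3 (0.15 log units; within the scatter), a size expected to stay within the usual scatter. The measurement must also be read against (the limit of > 10000 nM in this assay, at which 1 of the 2 values shown sits), and it may likewise come back only as a limit. The estimated value for compound 3 is 12000 nM, with an expected range from 5000 nM to 30000 nM.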

Compound 3, half-maximal inhibitory concentration: 9480 nM
Compound 3: middle estimate off by 1.3-fold (0.10 log units), on the high side; low and high end bracket the measured number.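

In this assay, among the compounds shown here, a 1.1-fold higher number from compound 2 to compound 3 (0.04 log units; within the scatter) is the first fully numerical comparison at this position, the aromatic carbon next to the ring nitrogen. It shows that removing piperazin-1-yl, with its six-membered non-aromatic ring and its hydrogen-bond donor and acceptors, and leaving only methyl produces no real change in the measured number. Methyl in place of 2-methylphenyl gives an at least 1.0-fold lower number from compound 1 to compound 3 (0.02 log units; that floor lies within the scatter), so this second step also offers no evidence of a real difference, and it stays a floor because compound 1 carries a limit and not a number: the limit of > 10000 nM in this assay, at which 1 of the 3 values shown sits.

As far as these compounds go, it remains open whether a different kind of group at this position, such as a carboxylic acid, a simple dimethylamino group or a longer chain, would move the number beyond the usual scatter. From the compounds shown here alone, it is also open whether any change elsewhere on the shared core would make the result of a swap at this position look different from what these three compounds show.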